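Replacing hydroxy with (methylamino)methyl in compound 3

A few compounds are considered here, and "the series" means these few. Any claim that something is new, unique, unknown or untested is made for them only; others in the source may bear on it.

Compound 1 `O=C(NCc1ccc(F)cc1)c1nc(Br)c2cccnc2c1NCc1ccc(F)cc1`: > 20000 nM (a limit)
Compound 2 `CN(C)CCCNc1c(C(=O)NCc2ccc(F)cc2)nc(Br)c2cccnc12`: > 10000 nM (a limit)
Compound 3 `O=C(NCc1ccc(F)cc1)c1nc(Br)c2cccnc2c1NCCO`: > 20000 nM (a limit)

In a functional assay on HCT-116 cells (Homo sapiens) for cytotoxicity, read by MTT assay, with a stated time of 72 h (on this read-out higher numbers stand for weaker inhibition and lower numbers for stronger inhibition), compound 3 gives > 20000 nM as a limit and not a number. Compound 3 thus stands at the limit of > 20000 nM in this assay, at which 2 of the 3 values shown sit, and cannot be ranked more finely. Compound 4 `CNCCCNc1c(C(=O)NCc2ccc(F)cc2)nc(Br)c2cccnc12` differs from compound 3 by (methylamino)methyl in place of hydroxy on a saturated chain carbon, two bonds along the chain from a nitrogen on an aromatic ring, with (methylamino)methyl in place of hydroxy on a saturated chain carbon, two bonds along the chain from a nitrogen on an aromatic ring.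

The nearest measured change at this place is a step that the two limits leave unreadable from compound 2 to compound 3. The other that bears on it is a step that the two limits leave unreadable from compound 1 to compound 3. Neither has a readable size, so no step beyond the scatter is expected in this assay, and no direction is expected either. The expected change is a number no higher from compound 3 to compound 4 (the limit leaves the size open). For compound 4 the estimate is 20000 nM, with an expected range from 6000 nM to 40000 nM.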

Compound 4, half-maximal inhibitory concentration: 9000 nM
Compound 4: middle estimate off by 2.2-fold (0.35 log units), on the high side, and the stated range covers the measured number.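

In this assay, compound 4 is the only compound shown with a number and not a limit, and its (3-(methylamino)propyl)amino group gives an at least 2.2-fold lower number from compound 3 to compound 4 (0.34 log units; beyond the scatter) and an at least 2.2-fold lower number from compound 1 to compound 4 (0.34 log units; beyond the scatter). Hydrogen in place of methyl on the amine nitrogen gives an at least 1.1-fold lower number from compound 2 to compound 4 (0.04 log units; that floor lies within the scatter), so this change has no size that clears the scatter. Compound 3 remains a limit, and the steps among compound 1, compound 2 and compound 3 cannot be read: the limit of > 20000 nM in this assay, at which 2 of the 4 values shown sit.

As far as these compounds go, whether a primary amine, a longer chain or a carboxylic acid at the chain end would shift the number stays open. So does the true distance between compound 2 and compound 4.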